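The source may hold more compounds than are shown below. What is called first, only, known or untested is meant among the compounds shown, and "the series" means these compounds.

Compound 1 `O=C1N=C(N2N=C(c3ccccc3)CC2c2ccccc2O)S/C1=C1/C(=O)Nc2ccccc21`: 4400 nM
Compound 2 `O=C1N=C(N2N=C(c3ccccc3)CC2c2ccccc2O)S/C1=C1/C(=O)Nc2ccc(Br)cc21`: 660 nM
Compound 3 `COc1ccc(C2CC(c3ccccc3)=NN2C2=NC(=O)/C(=C3\C(=O)Nc4ccc(Br)cc43)S2)cc1`: 550 nM

These three compounds share one core and were tested in a functional assay on cells (Melanoma cell, Homo sapiens) for cytotoxicity, read by sulforhodamine B assay, with a stated time of 48 h; a higher number here means a weaker inhibitor of growth, a lower number a stronger inhibitor of growth. Compound 1 gives the highest number of the three, with 4400 nM. The step of a 6.7-fold lower number from compound 1 to compound 2 (0.82 log units; beyond the scatter) puts a bromo group on an aromatic carbon, not at the saturated ring carbon that is of interest here. The step of a 1.2-fold lower number from compound 2 to compound 3 (0.08 log units; within the scatter) swaps the group on the saturated ring carbon, the same place that changes on the way to compound 4.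

Compound 4 `O=C1N=C(N2N=C(c3ccccc3)CC2c2ccc(Cl)cc2)S/C1=C1/C(=O)Nc2ccccc21` differs from compound 1 in one place: 4-chlorophenyl in place of 2-hydroxyphenyl on a saturated ring carbon. Among the measured compounds shown here, only the step from compound 2 to compound 3 bears directly on this kind of change, and it stayed within the scatter. The expectation is therefore that compound 4 sits close to compound 1, with at most a small move in this assay, estimated as a 1.3-fold lower number from compound 1 to compound 4 (0.10 log units; within the scatter). The estimate for compound 4 is 3500 nM, with a range from 1200 nM to 10000 nM.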

Compound 4, concentration for total growth inhibition: 540 nM
Estimate against measurement, compound 4: 6.5-fold (0.81 log units) above, and the stated range ends above it.
By their numbers in this assay, from the lowest: compounds 4, 3 and 2 (each within the scatter of the next); then compound 1.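

In this assay, the saturated ring carbon proves able to move the number clearly: 4-chlorophenyl in place of 2-hydroxyphenyl gives an 8.1-fold lower number from compound 1 to compound 4 (0.91 log units; beyond the scatter). The earlier change at this carbon, a 1.2-fold lower number from compound 2 to compound 3 (0.08 log units; within the scatter), stayed within the scatter, but that pair carries a bromo group and a different entering group, so the two steps differ in more than one way and the position's effect depends on at least one of these. Nothing measured here explains the step on the core of compound 1.

Going by these compounds, it remains open whether 4-chlorophenyl would give a similar step on the bromo-bearing core of compound 2. On these data alone, it is also open how a plain phenyl group, or a phenyl ring carrying an amine or a carboxylic acid, would behave at this carbon.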